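Notes on replacing methyl with pyridin-4-yl on a carbonyl carbon

The source may hold more compounds than are shown below. What is called first, only, known or untested is meant among the compounds shown, and "the series" means these compounds.

Measured so far in an ADME assay on Vero cells (Chlorocebus sabaeus) for cytotoxicity, read by MTT assay, with a stated time of 72 h; a higher number here means that more compound is tolerated, a lower number that less compound is tolerated
compound 1 `COc1c(N2CCN(CCC#N)C(C)C2)c(F)cc2c(=O)c(C(=O)O)cn(C3CC3)c12` gives 500 ug/mL
compound 2 `COc1c(N2CCN(C/C(C)=N/NC(N)=O)C(C)C2)c(F)cc2c(=O)c(C(=O)O)cn(C3CC3)c12` gives 500 ug/mL
compound 3 `COc1c(N2CCN(C/C(C)=N/NC(C)=O)C(C)C2)c(F)cc2c(=O)c(C(=O)O)cn(C3CC3)c12` gives 707 ug/mL

Compound 3 at 707 ug/mL lies within the scatter of both other compounds in this assay and so has no clear rank among them. Next comes compound 4 `COc1c(N2CCN(C/C(C)=N/NC(=O)c3ccncc3)C(C)C2)c(F)cc2c(=O)c(C(=O)O)cn(C3CC3)c12` with the change pyridin-4-yl in place of methyl on a carbonyl carbon that is, pyridin-4-yl in place of methyl on a carbonyl carbon. The closest measured change, methyl in place of amino at that same carbon, is a 1.4-fold higher number from compound 2 to compound 3 (0.15 log units; within the scatter) and stays within the scatter. The two larger exchanges on the chain, no change at the digits printed from compound 1 to compound 2 (within the scatter) and a 1.4-fold higher number from compound 1 to compound 3 (0.15 log units; within the scatter) also stay within it. For the measured compounds named here, no measured step places a ring on this carbonyl carbon, so this evidence reaches the new group only loosely and the range is kept wide. No step beyond the scatter is expected, and the estimated step is a 1.4-fold lower number from compound 3 to compound 4 (0.15 log units; within the scatter) without a firm direction. For compound 4 the estimated value is 500 ug/mL with an expected range of 220 ug/mL to 1000 ug/mL in this assay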

Compound 4, half-maximal cytotoxic concentration: 250 ug/mL
The estimate for compound 4 lay 2.0-fold (0.30 log units) above the measured number; the range from low to high includes it.
By their numbers in this assay, from the lowest: compounds 4, 1, 2 and 3 (each within the scatter of the next, the first and the last beyond it).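

In this assay, for the compounds shown here, pyridin-4-yl in place of methyl on the carbonyl carbon gives the first step beyond the scatter, a 2.8-fold lower number from compound 3 to compound 4 (0.45 log units; beyond the scatter), so this position is not as indifferent to exchange as the earlier compounds suggested. The other two steps, a 2.0-fold lower number from compound 2 to compound 4 (0.30 log units; within the scatter) and a 2.0-fold lower number from compound 1 to compound 4 (0.30 log units; within the scatter), stay within the scatter, so the separation holds against the methyl group alone and rests on a single pair. Nothing measured on these compounds accounts for the step.

On these data alone, whether a phenyl or a pyridin-3-yl group on this carbonyl carbon would give a step of similar size remains open, which leaves the part played by the ring nitrogen undefined. Also open, as far as these compounds go, is whether an ethyl group or a longer chain at the same carbon would already give part of this step, or whether only a ring does so.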